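A few compounds are considered here, and "the series" means these few. Any claim that something is new, unique, unknown or untested is made for them only; others in the source may bear on it.

Measured in an ADME assay on Vero cells (Chlorocebus sabaeus) for inhibition; a higher number here means that more compound is tolerated, a lower number that less compound is tolerated:
- compound 1 `COc1ccc(/C=C2\CCC/C(=C\c3ccc(OC)cc3)C2=O)cc1`: 178000 nM
- compound 2 `O=C1/C(=C/c2ccccc2Cl)CCC/C1=C\c1ccccc1Cl`: 30600 nM
- compound 3 `COc1ccc(/C=C2\CCC/C(=C\c3ccccc3)C2=O)cc1`: 291000 nM

Compound 3 and compound 1 sit together at the well-tolerated end of this small set, within the scatter of each other, while compound 2 is clearly lower than both.

The next compound, compound 4 `COc1ccc(/C=C2\CCC/C(=C\c3ccc(N(C)C)cc3)C2=O)cc1`, keeps the rest of compound 3 and changes one thing: dimethylamino in place of hydrogen on an aromatic carbon. Put simply, this is dimethylamino in place of hydrogen on an aromatic carbon.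

Within the data shown here, only one measured step involves a swap on an aromatic carbon with hydrogen as one partner: a 1.6-fold higher number from compound 1 to compound 3 (0.21 log units; within the scatter), with hydrogen in place of methoxy. Among the measured compounds shown here, that step is small, but it is a single step, and no compound with dimethylamino has been measured yet. Resting on it, no change beyond the scatter is expected in this assay. The estimated step is a 1.8-fold lower number from compound 3 to compound 4 (0.26 log units; within the scatter). For compound 4 the expected value is 160000 nM, with an estimated range from 50000 nM to 400000 nM.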

Compound 4, half-maximal cytotoxic concentration: 392000 nM
The estimate for compound 4 lay 2.5-fold (0.39 log units) below the measured number; the measured number falls inside the stated range.
By their numbers in this assay, from the lowest: compound 2; then compounds 1, 3 and 4 (each within the scatter of the next, the first and the last beyond it).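

In this assay, a group of 3 heavy atoms on this aromatic carbon, para to a large group, gives a 1.3-fold higher number from compound 3 to compound 4 (0.13 log units; within the scatter) and so stays within the scatter of the bare hydrogen. Among these compounds, the comparison with methoxy at the same place gives a 2.2-fold higher number from compound 1 to compound 4 (0.34 log units; beyond the scatter) and, though modest, is the first step at this position to go beyond the scatter, while hydrogen in compound 3 remains within the scatter of both groups. No measurement here bears on the reason for this result.

Going by these compounds, whether this position would accept a primary amine, a carboxylic acid or a longer chain remains open. Compound 2 differs from the others in more than one place, so the compounds shown cannot tie its lower number to any single change.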